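A Dichlorophenyl Sulfonamide Awaits Its Thromboxane Receptor Test

A few compounds are considered here, and "the series" means these few. Any claim that something is new, unique, unknown or untested is made for them only; others in the source may bear on it.

Of the compounds shown here, three sharing one core have been measured in a functional assay on a cell-free system (plasma) for inhibition of thromboxane A2 receptor (Homo sapiens), read by turbidimetry; a lower number here means a stronger inhibitor, a higher number a weaker inhibitor. Compound 1, `O=C(O)CC/C=C\CC1=CCC[C@@H]1NS(=O)(=O)c1ccccc1`, gives 2200 nM. Compound 2, `O=C(O)CCC/C=C\CC1=CCC[C@@H]1NS(=O)(=O)c1ccccc1`, gives 2300 nM in this assay, and compound 3, `O=C(O)COCCCCC1=CCC[C@@H]1NS(=O)(=O)c1ccccc1`, gives 2000 nM. Compound 1 stands second highest of these three numbers, nearest to compound 2 with a 1.0-fold higher number from compound 1 to compound 2 (0.02 log units; within the scatter), and furthest from compound 3 with a 1.1-fold lower number from compound 1 to compound 3 (0.04 log units; within the scatter). The step of a 1.2-fold lower number from compound 2 to compound 3 (0.06 log units; within the scatter) is likewise within the scatter, so the three acid chains behave alike in this assay.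

Compound 4, `O=C(O)CC/C=C\CC1=CCC[C@@H]1NS(=O)(=O)c1ccc(Cl)c(Cl)c1`, has not yet been measured. It differs from compound 1 in one place: 3,4-dichlorophenyl in place of phenyl on a sulfonyl sulfur. Within the data shown here, every measured step concerns the acid chain on the other side of the core, so no measured step bears on this change, and the data give no guide to its direction or size. The expectation therefore rests on compound 1 alone. Compound 4 is expected to give about 1500 nM in this assay, with a range from 300 nM to 7000 nM. For compound 4 this estimate means a 1.5-fold lower number from compound 1 to compound 4 (0.17 log units; within the scatter), a step expected to stay within the scatter.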

Compound 4, half-maximal inhibitory concentration: 1900 nM
For compound 4 the middle estimate is 1.3-fold (0.10 log units) below the measured one; low and high end bracket the measured number.
By their numbers in this assay, from the lowest: compounds 4, 3, 1 and 2 (each within the scatter of the next).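

Compound 4 gives the first measured change away from the acid chain, and 3,4-dichlorophenyl in place of phenyl on the sulfonyl sulfur yields a 1.2-fold lower number from compound 1 to compound 4 (0.06 log units; within the scatter) in this assay on this swap. So this position, like the acid chain across compound 1, compound 2 and compound 3, has so far shown no step beyond the scatter, even with two chlorine atoms entering. No evidence at hand speaks to a cause for this result.

From the compounds shown here alone, it remains open whether a different group on the sulfonyl sulfur, such as a naphthyl ring, a pyridine ring or a plain methyl, would move the number beyond the scatter. The compounds shown also leave open how 3,4-dichlorophenyl would read with the 5-carboxypent-1-en-1-yl chain of compound 2 or the 3-(carboxymethoxy)propyl chain of compound 3.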